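A few compounds are considered here, and "the series" means these few. Any claim that something is new, unique, unknown or untested is made for them only; others in the source may bear on it.

Measured so far:
- compound 1, `CC1=C(C(=O)Nc2ccc(Br)cc2)C(c2ccc(Cl)cc2Cl)N=C(SCc2ccccc2)N1`, 17.4%
- compound 2, `CC1=C(C(=O)Nc2ccc(Br)cc2)C(c2ccc(Cl)cc2Cl)N=C(SCc2cccc(Cl)c2)N1`, 15.4%
- compound 3, `COc1ccc(C2N=C(SCc3ccccc3)NC(C)=C2C(=O)Nc2ccc(Br)cc2)cc1`, 11.3%

These three compounds were tested in a functional assay on the whole organism (artery, strain albino) with Rattus norvegicus as the target, with a stated time of 600 min, at a dose of 10 mg/kg by the oral route; on this read-out lower numbers stand for less inhibition and higher numbers for more inhibition at the one dose given (going by the name of the read-out). Compound 3 gives the lowest of the three numbers, but its gap to compound 2 and its gap to compound 1 both lie within the usual scatter, so the three cannot be ranked against one another on this read-out.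

Compound 4, `COc1ccc(C2N=C(SCc3cccc(Cl)c3)NC(C)=C2C(=O)Nc2ccc(Br)cc2)cc1`, has not yet been measured. It differs from compound 3 in one place: chloro in place of hydrogen on an aromatic carbon. The same kind of change has been measured once before, on a different partner: a number 2 percentage points lower from compound 1 to compound 2 (within the scatter). That step was small and inside the scatter, so there is no sign that adding chloro at this position moves the read-out in this assay by a real amount.

On this basis, compound 4 is expected to stay close to compound 3 in this assay, with an estimated step of a number 1.3 percentage points lower from compound 3 to compound 4 (within the scatter), which is not expected to exceed the scatter. The estimated value for compound 4 is 10%, with a likely range from 2% to 20%.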

Compound 4, a percentage reported as inhibition, in the whole organism at one dose (the size of the read-out at that dose, not a potency): 32.8%
For compound 4 the middle estimate is 22.8 percentage points below the measured one; measured number above the stated range.
By their numbers in this assay, from the lowest: compounds 3, 2 and 1 (each within the scatter of the next); then compound 4.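

In this assay, the chloro in the change from benzyl to 3-chlorobenzyl has no fixed effect of its own, since on the 4-methoxyphenyl partner it gives a number 21.5 percentage points higher from compound 3 to compound 4 (beyond the scatter), a step beyond the scatter, and the earlier pair gave no such sign: the same change on two cores in this assay, a number 2 percentage points lower (within the scatter) from compound 1 to compound 2 and a number 21.5 percentage points higher (beyond the scatter) from compound 3 to compound 4, 23.5 percentage points apart, beyond the scatter of two such steps. The other change shows the same dependence, since 4-methoxyphenyl in place of 2,4-dichlorophenyl gives a number 17.4 percentage points higher from compound 2 to compound 4 (beyond the scatter) when the 3-chlorobenzyl group is present, but no step beyond the scatter when plain benzyl is present: the same change on two cores in this assay, a number 6.1 percentage points lower (within the scatter) from compound 1 to compound 3 and a number 17.4 percentage points higher (beyond the scatter) from compound 2 to compound 4, 23.5 percentage points apart, beyond the scatter of two such steps. The two places therefore do not act independently in these four compounds, and the result of a change at one place can be read only together with the group at the other, so a step measured on one partner cannot simply be carried over to another.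

The compounds shown leave open whether this rise belongs to chloro in particular or would also appear with a fluoro, a methyl or an amine on the same aromatic carbon of the 4-methoxyphenyl series. They also cannot tell why the two groups work together, and a read-out at a single dose gives the size of the inhibition at that dose, not a potency.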